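The source may hold more compounds than are shown below. What is called first, only, known or untested is meant among the compounds shown, and "the series" means these compounds.

Measured in a functional assay on A549 cells (Homo sapiens) for antiproliferative activity, read by CCK-8 assay, with a stated time of 72 h; a lower number here means a stronger inhibitor, a higher number a weaker inhibitor:

Compound 1 `Nc1ccccc1NC(=O)c1ccc(COc2ccc(Br)cc2)cc1`: 24400 nM
Compound 2 `Nc1ccccc1NC(=O)c1ccc(COc2ccc(Cl)cc2)cc1`: > 32000 nM
Compound 3 `Cc1ccc(OCc2ccc(C(=O)Nc3ccccc3N)cc2)cc1`: 5430 nM

Compound 2 gives > 32000 nM, which is a limit of the assay and not a number. Compound 3 has the lowest value of the set, so it is the strongest inhibitor here, with a 4.5-fold lower number from compound 1 to compound 3 (0.65 log units; beyond the scatter). Compound 4 `CC(C)c1ccc(OCc2ccc(C(=O)Nc3ccccc3N)cc2)cc1` changes one group of compound 3: isopropyl in place of methyl on an aromatic carbon. In words, isopropyl sits in place of methyl on an aromatic carbon.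

Two measured steps changed the group at this same place. One is the step already given, and the other is an at least 5.8-fold lower number from compound 2 to compound 3 (0.77 log units; beyond the scatter). Both show that this group can shift the number modestly, but both replace a halogen with methyl. Within the data shown here, no measured step enlarges the methyl, so neither sets a direction for compound 4. A modest step in either direction is expected, and no step beyond the scatter is equally possible. For compound 4 the estimated value is 5000 nM, with an expected range of 1500 nM to 18000 nM. This estimate means a 1.1-fold lower number from compound 3 to compound 4 (0.04 log units; within the scatter).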

Compound 4, half-maximal inhibitory concentration: 7460 nM
The estimate for compound 4 lay 1.5-fold (0.17 log units) below the measured number; the range from low to high includes it.
By their numbers in this assay, from the lowest: compounds 3 and 4 (each within the scatter of the next); then compound 1. At a limit, above all of these: compound 2.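

Placing the larger isopropyl where methyl stood, on an aromatic carbon para to a large group, gives a 1.4-fold higher number from compound 3 to compound 4 (0.14 log units; within the scatter) in this assay, so this enlargement leaves the number within the scatter. Isopropyl also stays clearly apart from both halogens, with a 3.3-fold lower number from compound 1 to compound 4 (0.51 log units; beyond the scatter) and an at least 4.2-fold lower number from compound 2 to compound 4 (0.63 log units; beyond the scatter), which means that methyl and isopropyl both give lower numbers than bromo and chloro. Compound 2 stands at a limit of the assay and not at a number: the limit of > 32000 nM in this assay, at which 1 of the 4 values shown sits.

The compounds shown do not tell whether a still bulkier carbon group, such as tert-butyl or a phenyl ring, would keep the number at this level. They also leave open what a group of another kind at this place, such as an amine or a carboxylic acid, would do.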